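This account rests on a few compounds, and the source may have more. Where it says the series, first, only, none or still open, it means among the compounds named here.

In an assay on HEK-293T cells for inhibition of diacylglycerol lipase-alpha (Homo sapiens), read by colorimetric assay (a lower number here means a stronger inhibitor, a higher number a weaker inhibitor), compound 1 `O=C(CCCCCCc1ccccc1)c1nc(-c2ccco2)no1` gives 933 nM. Compound 2 `O=C(CCCCCCc1ccccc1)c1nc(-c2ccccn2)no1` differs from it by pyridin-2-yl in place of furan-2-yl on an aromatic carbon, and in this assay compound 2 gives 2750 nM. That change made a 2.9-fold higher number from compound 1 to compound 2 (0.47 log units; beyond the scatter). Compound 3 `O=C(CCCCCCc1ccccc1)c1noc(-c2ccco2)n1` is built from the same atoms as compound 1, joined differently; the difference between the two cores is not broken down here. In this assay compound 3 gives only a limit, > 10000 nM, which is the limit of > 10000 nM in this assay, at which 1 of the 3 values shown sits.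

Compound 4 `O=C(CCCCCCc1ccccc1)c1noc(-c2ccccn2)n1` has not yet been measured. Relative to compound 3 it carries pyridin-2-yl in place of furan-2-yl on an aromatic carbon. For the measured compounds named here, this is the same kind of change as the one seen between compound 1 and compound 2, but the surroundings of the place are not identical: in compound 1 the carbon lies between two ring nitrogen atoms and two ring bonds from the ring oxygen, whereas in compound 3 it lies next to the ring nitrogen, next to the ring oxygen and two ring bonds from the ring nitrogen. In this assay the expected step is a step that the limit leaves unreadable from compound 3 to compound 4. That expectation rests on a 2.9-fold higher number from compound 1 to compound 2 (0.47 log units; beyond the scatter), which pointed toward a higher number, and on compound 3 already sitting at the limit of > 10000 nM in this assay, at which 1 of the 3 values shown sits. Compound 4 is therefore estimated at 30000 nM, with a range from 10000 nM to 100000 nM, and the assay is expected most likely to report only a limit.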

Compound 4, half-maximal inhibitory concentration: > 10000 nM
Compound 4 ended at the assay's limit; the forecaster's own chance of this, stated with the estimate: 85%; the middle value lies beyond the limit too.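

In this assay compound 4 gives > 10000 nM, which is a limit of the assay and not a number. For the compounds shown here, compound 3 stands at the same limit, so no step from compound 3 to compound 4 can be read: the limit of > 10000 nM in this assay, at which 2 of the 4 values shown sit. The compounds shown leave open how far apart compound 3 and compound 4 lie, and whether pyridin-2-yl in place of furan-2-yl acts on their shared core as it did on the core of compound 1.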